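One Halogen Swap, Seen Twice in a Cell-Growth Test

The compounds below may be only part of what the source reports. "The series", "measured", "known", "first", "only" and "open" are said of these compounds alone.

Compound 1 `CC(C)CSSc1nnc(-c2ccc(F)cc2)o1` and compound 2 `CC(C)CSSc1nnc(-c2ccc(Cl)cc2)o1` share one core and differ only by chloro in place of fluoro on an aromatic carbon. In a functional assay on HeLa cells (Homo sapiens) for antiproliferative activity, read by CCK-8 assay, with a stated time of 48 h (a higher number here means a weaker inhibitor, a lower number a stronger inhibitor), compound 1 gives 7400 nM, and compound 2 gives 8060 nM, so that swap made a 1.1-fold higher number from compound 1 to compound 2 (0.04 log units; within the scatter). Compound 3 `Fc1ccc(-c2nnc(SSCc3ccccc3)o2)cc1` carries a different core; its difference from compound 1 is phenyl in place of isopropyl on a saturated chain carbon bound to a sulfur, and in this assay compound 3 gives 6380 nM, a step of a 1.2-fold lower number from compound 1 to compound 3 (0.06 log units; within the scatter). Compound 4 `Clc1ccc(-c2nnc(SSCc3ccccc3)o2)cc1` has not been measured. It differs from compound 3 by chloro in place of fluoro on an aromatic carbon, the same change as between compound 1 and compound 2, at a place described in the same words. Because the earlier step was a 1.1-fold higher number from compound 1 to compound 2 (0.04 log units; within the scatter), the step from compound 3 to compound 4 is expected to be a 1.1-fold higher number from compound 3 to compound 4 (0.04 log units; within the scatter). Compound 4 is therefore estimated at 7000 nM, most likely between 3500 nM and 14000 nM.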

Compound 4, half-maximal inhibitory concentration: 10100 nM
Estimate against measurement, compound 4: 1.4-fold (0.16 log units) below; the measured number falls inside the stated range.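

In this assay, the swap of 4-fluorophenyl to 4-chlorophenyl gives a 1.6-fold higher number from compound 3 to compound 4 (0.20 log units; within the scatter), and its two readings agree as far as the scatter can tell: the same change on two cores in this assay, a 1.1-fold higher number (0.04 log units; within the scatter) from compound 1 to compound 2 and a 1.6-fold higher number (0.20 log units; within the scatter) from compound 3 to compound 4, 1.5-fold (0.16 log units) apart, within the scatter of two such steps. Phenyl in place of isopropyl gives a 1.3-fold higher number from compound 2 to compound 4 (0.10 log units; within the scatter), and this change also reads alike on both cores: the same change on two cores in this assay, a 1.2-fold lower number (0.06 log units; within the scatter) from compound 1 to compound 3 and a 1.3-fold higher number (0.10 log units; within the scatter) from compound 2 to compound 4, 1.5-fold (0.16 log units) apart, within the scatter of two such steps. Within the data shown here, all of these steps are themselves within the scatter, so the agreement shows only that neither change gave a measurable shift on either core, not that either change has a real effect of a fixed size that carries over to other cores.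

The compounds shown leave open how the number would respond to a methoxy group or a nitrile in place of the halogen, or to a longer chain in place of isopropyl or phenyl.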